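The compounds below may be only part of what the source reports. "The series", "measured", "known", "first", "only" and "open" are said of these compounds alone.

Measured so far in an ADME assay on S9 fraction from liver (Mus musculus, strain ICR/CD-1) for metabolic stability, read by LC-MS, using NADPH, with a stated time of 5 min, tested at 2 uM; on this read-out higher numbers stand for a longer-lived compound and lower numbers for a shorter-lived compound:
- compound 1 `CC1CCN(C2CCN(S(=O)(=O)c3cccc4ccccc34)CC2)CC1`: < 0.0834 h
- compound 2 `COc1ccccc1-c1cccc(S(=O)(=O)N2CCC(N3CCC(C)CC3)CC2)c1`: 0.25 h

Compound 1 shows < 0.0834 h, which is a limit of the assay and not a number.

For the measured compounds named here, compound 2 gives the only true number, a half-life of 0.25 h, and it is therefore the sole numerical anchor for the next comparison.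

Compound 3 `CC1CCN(C2CCN(S(=O)(=O)c3cccc(-c4ccc(F)cc4)c3)CC2)CC1` is not yet measured. It carries 4-fluorophenyl in place of 2-methoxyphenyl on an aromatic carbon, meta to a large group: 4-fluorophenyl in place of 2-methoxyphenyl on an aromatic carbon.

Going by the values given here, no measured pair differs in one place only, so the data give no direct size for this kind of change. Without such a guide, no shift beyond the usual scatter of this assay is expected in either direction. The expected result is a small step of a 1.1-fold lower number from compound 2 to compound 3 (0.06 log units; within the scatter), and it stays within that scatter.

Compound 3 is estimated at 0.22 h, with an expected range from 0.09 h to 0.5 h.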

Compound 3, half-life: 1.28 h
Beside the measured number, compound 3's estimate is 5.8-fold (0.76 log units) below it; the measured number lies above the stated range.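

Putting 4-fluorophenyl in place of 2-methoxyphenyl on an aromatic carbon, meta to a large group, gives a 5.1-fold higher number from compound 2 to compound 3 (0.71 log units; beyond the scatter) in this assay. For the compounds shown here, this is the first single change whose size can be read, and it shows that the half-life responds to the group held at this place, with the step lying beyond the usual scatter. The change takes away the hydrogen-bond acceptor of the leaving group and brings in a group with none, but no measurement shown gives a cause for the step, so that difference remains a description and not an explanation.

A single step cannot show whether the rise follows the loss of 2-methoxyphenyl or the arrival of 4-fluorophenyl, and plain phenyl or 4-methoxyphenyl at this place would be the comparisons that separate the two. Also open, going by these compounds, is how far the trend carries to other groups on the same ring, such as a nitrile or a trifluoromethyl in place of the fluorine, or an amine, which would test this place with a quite different substituent.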